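This account rests on a few compounds, and the source may have more. Where it says the series, first, only, none or still open, it means among the compounds named here.

Compound 2 `C#CCN(Cc1cc2c(O)nc(C)nc2cc1C)c1ccc(C(=O)N[C@@H](CCC(=O)O)C(=O)N(CC#C)[C@@H](CCC(=O)O)C(=O)O)c(F)c1` gives 0.21 nM in an assay on L1210 cells for inhibition of Thymidylate synthase (Mus musculus) (on this read-out lower numbers stand for stronger inhibition and higher numbers for weaker inhibition), the lowest of the three numbers recorded. Compound 1 `C#CCN(Cc1cc2c(O)nc(C)nc2cc1C)c1ccc(C(=O)N[C@@H](CCC(=O)O)C(=O)N(C)[C@@H](CCC(=O)O)C(=O)O)c(F)c1` gives 1.1 nM in this assay, and compound 3 `Cc1nc(O)c2cc(CN(C)c3ccc(C(=O)N[C@@H](CCC(=O)O)C(=O)N(C)[C@@H](CCC(=O)O)C(=O)O)c(F)c3)c(C)cc2n1` gives 3 nM. Compound 4 `C#CCN(Cc1cc2c(O)nc(C)nc2cc1C)c1ccc(C(=O)N[C@@H](CCC(=O)O)C(=O)N(CC)[C@@H](CCC(=O)O)C(=O)O)c(F)c1` differs from compound 2 by methyl in place of ethynyl on a saturated chain carbon bound to an amide-type nitrogen, which read one bond further out is propargyl to ethyl. The step that bears on this place is a 5.2-fold lower number from compound 1 to compound 2 (0.72 log units; beyond the scatter), where hydrogen became ethynyl at the same amide-type nitrogen. The other step, a 2.7-fold higher number from compound 1 to compound 3 (0.44 log units; beyond the scatter), concerns a different place and is less informative. Since compound 4 carries ethyl rather than the methyl of compound 1 or the propargyl of compound 2, compound 4 is expected to show a 2.6-fold higher number from compound 2 to compound 4 (0.42 log units; beyond the scatter). Compound 4 is therefore estimated at 0.55 nM, within 0.22 nM to 1.4 nM.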

Compound 4, inhibition constant: 0.35 nM
Beside the measured number, compound 4's estimate is 1.6-fold (0.20 log units) above it; the range from low to high includes it.
By their numbers in this assay, from the lowest: compounds 2 and 4 (each within the scatter of the next); then compound 1; then compound 3.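

In this assay, an ethyl chain on the amide-type nitrogen is already enough to separate the compound from the methyl analogue, with a 3.1-fold lower number from compound 1 to compound 4 (0.50 log units; beyond the scatter). Exchanging propargyl for ethyl gives a 1.7-fold higher number from compound 2 to compound 4 (0.22 log units; within the scatter), so the triple bond is not needed for the low numbers seen at this position. Nothing given here explains this result. Going by these compounds, it remains open whether a longer chain, such as propyl or butyl, would keep these numbers at this nitrogen. A chain ending in an amine or a carboxylic acid is also untested in the compounds shown.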